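The source may hold more compounds than are shown below. What is called first, only, known or untested is meant among the compounds shown, and "the series" means these compounds.

In an ADME assay on HeLa cells (Homo sapiens) for cytotoxicity, read by MTT assay (on this read-out lower numbers stand for stronger inhibition and higher numbers for weaker inhibition), three compounds on a shared core have been measured so far. Compound 1 `COc1ccc(C[C@H]2COC(=O)[C@@H]2Cc2ccc(OCC(=O)N3CCCCC3)c(OC)c2)cc1OC` gives 293000 nM and compound 3 `COc1ccc(C[C@H]2COC(=O)[C@@H]2Cc2ccc(OCc3cn(-c4cccc(Cl)c4)nn3)c(OC)c2)cc1OC` gives 493000 nM so compound 3 stands level with compound 1 within the scatter (a 1.7-fold higher number from compound 1 to compound 3 (0.23 log units; within the scatter)). Compound 2 `COc1ccc(C[C@H]2COC(=O)[C@@H]2Cc2ccc(OCC(=O)N3CCCC3)c(OC)c2)cc1OC` gives >= 600000 nM as a limit of the assay and not as a number.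

Compound 4 `COc1ccc(C[C@H]2COC(=O)[C@@H]2Cc2ccc(OCc3cn(Cc4ccccc4)nn3)c(OC)c2)cc1OC` has not yet been measured. Its change from compound 3 (benzyl in place of 3-chlorophenyl on an aromatic nitrogen) is benzyl in place of 3-chlorophenyl on an aromatic nitrogen. Going by the values given here, no measured step alters that group alone. The closest evidence comes from exchanges of the whole side group, one of which stays within the scatter (a 1.7-fold higher number from compound 1 to compound 3 (0.23 log units; within the scatter)) while the other has a floor within it (an at least 1.2-fold lower number from compound 2 to compound 3 (0.08 log units; that floor lies within the scatter)). Among the compounds with values here, the only step beyond the scatter (an at least 2.0-fold higher number from compound 1 to compound 2 (0.31 log units; beyond the scatter)) is pyrrolidin-1-yl in place of piperidin-1-yl on a carbonyl carbon, a different part of the molecule, and it ends at a limit (the limit of >= 600000 nM in this assay, at which 1 of the 3 values shown sits). It therefore offers no guide to the size of this change. With those side-group exchanges as the guide, no shift beyond the scatter is expected in this assay in either direction. The expected step is small (a 1.2-fold lower number from compound 3 to compound 4 (0.09 log units; within the scatter)) and stays within the scatter. Compound 4 is estimated at 400000 nM (from 180000 nM to 800000 nM).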

Compound 4, half-maximal inhibitory concentration: 346000 nM
Compound 4: the middle estimate sits 1.2-fold (0.06 log units) above what was measured; the measured number falls inside the stated range.
By their numbers in this assay, from the lowest: compounds 1, 4 and 3 (each within the scatter of the next). At a limit, above all of these: compound 2.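

In this assay, the exchange on an aromatic nitrogen of the five-membered aromatic ring with 3 nitrogen can now be read by itself: benzyl in place of 3-chlorophenyl gives a 1.4-fold lower number from compound 3 to compound 4 (0.15 log units; within the scatter) and so leaves the read-out unchanged within the scatter, although the chlorine is gone and the aromatic ring is now held on that nitrogen through a carbon. The side group as a whole also cannot be told apart from the amide side group of compound 1, with 1-benzyl-1H-1,2,3-triazol-4-yl in place of (piperidin-1-yl)carbonyl giving a 1.2-fold higher number from compound 1 to compound 4 (0.07 log units; within the scatter) in the same assay. The remaining exchange, an at least 1.7-fold lower number from compound 2 to compound 4 (0.23 log units; that floor lies within the scatter), gives only a floor, as its starting value is a limit of the assay: the limit of >= 600000 nM in this assay, at which 1 of the 4 values shown sits.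

Going by these compounds, the loss of the chlorine and the insertion of the carbon come together in this single step, so the effect of each alone stays open. Also open, on these data alone, is whether a plain phenyl, a 2-phenylethyl chain or a benzyl carrying an amine on that aromatic nitrogen would move the number beyond the scatter in this assay at all.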